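Trifluoromethyl in Place of Chloro: Compound 1 to Compound 4

This account rests on a few compounds, and the source may have more. Where it says the series, first, only, none or still open, it means among the compounds named here.

In a functional assay on OVCAR-5 cells (Homo sapiens) for inhibition, read by sulforhodamine B assay, with a stated time of 48 h (a higher number here means a weaker inhibitor of growth, a lower number a stronger inhibitor of growth), compound 1 `O=C(Nc1cccc(-n2cc(-c3ccncc3)c(-c3ccc(Cl)c(O)c3)n2)c1)Nc1ccc(Cl)c(Cl)c1` gives only a limit, > 32500 nM, and no number, as noted in the limit of > 32500 nM in this assay, at which 1 of the 3 values shown sits. Compound 2 `O=C(Nc1cccc(-n2cc(-c3ccncc3)c(-c3ccc(Cl)c(O)c3)n2)c1)Nc1cc(C(F)(F)F)cc(C(F)(F)F)c1` gives 2030 nM in this assay, and compound 3 `COc1cc(-c2nn(-c3cccc(NC(=O)Nc4cccc(C(F)(F)F)c4)c3)cc2-c2ccncc2)ccc1Cl` gives 6450 nM. Each of these two carries trifluoromethyl and each returns a number rather than a limit. Compound 4 `O=C(Nc1cccc(-n2cc(-c3ccncc3)c(-c3ccc(Cl)c(O)c3)n2)c1)Nc1ccc(Cl)c(C(F)(F)F)c1` has not yet been measured in this assay. It differs from compound 1 by trifluoromethyl in place of chloro on an aromatic carbon, the entering trifluoromethyl sitting ortho to a chloro group. Among the measured compounds shown here, no measured step between compounds exists here, so the expectation rests on compounds 2 and 3 alone: a downward step, beyond the usual scatter, toward stronger inhibition. Compound 4 is estimated at 5000 nM in this assay, between 1500 nM and 20000 nM. The expected step is an at least 6.5-fold lower number from compound 1 to compound 4 (0.81 log units; beyond the scatter).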

Compound 4, concentration for total growth inhibition: 16200 nM
For compound 4 the middle estimate is 3.2-fold (0.51 log units) below the measured one; the range from low to high includes it.
By their numbers in this assay, from the lowest: compound 2; then compound 3; then compound 4. At a limit, above all of these: compound 1.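

Trifluoromethyl in place of chloro, ortho to a chloro group, gives the only single change at this position that can be read in this assay: the step is an at least 2.0-fold lower number from compound 1 to compound 4 (0.30 log units; that floor lies within the scatter). Compound 4 keeps its chloro group and still returns a number. The size of the step remains only a floor because compound 1 rests on a limit of the assay: the limit of > 32500 nM in this assay, at which 1 of the 4 values shown sits.

On these data alone, how a methyl group, a nitrile or an amine would read at this position remains open. So does whether this change would give a similar step on another core.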